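This account rests on a few compounds, and the source may have more. Where it says the series, first, only, none or still open, it means among the compounds named here.

Measured so far:
- Compound 1 `Cc1c(C(=O)Nc2ccc(Oc3ccnc4[nH]ccc34)c(F)c2)nnn1-c1ccc(F)cc1`: in a functional assay on PC-3 cells (Homo sapiens) for cytotoxicity, read by MTT assay, with a stated time of 72 h (a higher number here means a weaker inhibitor, a lower number a stronger inhibitor), compound 1 gives 4350 nM.
- Compound 2 `Cc1c(C(=O)Nc2ccc(Oc3ccnc4[nH]ccc34)c(F)c2)nnn1-c1ccc(F)c(F)c1`: in this assay compound 2 gives 6540 nM.
- Compound 3 `Cc1c(C(=O)Nc2ccc(Oc3ccnc4[nH]ccc34)cc2)nnn1-c1ccccc1`: in this assay compound 3 gives 7260 nM.

All three compounds share an amide that joins a triazole carrying a phenyl group to a larger aryl ether part. Compound 1 and compound 2 share one core; compound 3 has another, and the difference between the two cores is not broken down here. The step from compound 1 to compound 2 is fluoro in place of hydrogen on an aromatic carbon, and it gave a 1.5-fold higher number from compound 1 to compound 2 (0.18 log units; within the scatter).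

The unmeasured compound 4 `Cc1c(C(=O)Nc2ccc(Oc3ccnc4[nH]ccc34)cc2)nnn1-c1ccccc1F` is made from compound 3 by fluoro in place of hydrogen on an aromatic carbon. For the measured compounds named here, this is the same kind of change as the one from compound 1 to compound 2, but not the same: in compound 2 the new fluoro sits ortho to a fluoro group and meta to a large group, whereas in compound 4 it sits ortho to a large group, on a ring that carries no other fluoro.

Going by the values given here, with only one earlier example of this kind of change, and that one within the scatter, the expectation for compound 4 rests on compound 3 and on the small size of a 1.5-fold higher number from compound 1 to compound 2 (0.18 log units; within the scatter): a small step is expected, a 1.2-fold higher number from compound 3 to compound 4 (0.07 log units; within the scatter), which is within the scatter. Compound 4 is therefore estimated at 8500 nM, likely between 4000 nM and 18000 nM.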

Compound 4, half-maximal inhibitory concentration: 3450 nM
For compound 4 the middle estimate is 2.5-fold (0.39 log units) above the measured one, and the stated range ends above it.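

Replacing a hydrogen with fluoro, here turning phenyl into 2-fluorophenyl with the new fluoro ortho to a large group, gave a 2.1-fold lower number from compound 3 to compound 4 (0.32 log units; beyond the scatter) in this assay. This shows that the change does not carry a single fixed effect from one core to another in this series, since the two steps differ in direction and the gap between them is larger than repeated measurements alone would be expected to produce: the same change on two cores in this assay, a 1.5-fold higher number (0.18 log units; within the scatter) from compound 1 to compound 2 and a 2.1-fold lower number (0.32 log units; beyond the scatter) from compound 3 to compound 4, 3.2-fold (0.50 log units) apart, beyond the scatter of two such steps

It does not show that the core alone sets the outcome, since the new fluoro also sits in a different place in each step, so this pair cannot separate the core from the position, and two steps make no general rule.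

From the compounds shown here alone, what stays open is how the 2-fluorophenyl group would behave on the core of compound 1, a comparison that would hold the position fixed and vary only the core. Also open, going by these compounds, is whether a chloro or a methoxy group in the place of the fluoro of compound 4 would move the number in the same direction.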